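A few compounds are considered here, and "the series" means these few. Any claim that something is new, unique, unknown or untested is made for them only; others in the source may bear on it.

Going by the values given here, compound 2 `COc1ccccc1N1CCN(CCn2nc(-n3ccnc3)ccc2=O)CC1` gives 237 nM in an assay on cell membranes from brain for binding affinity to Adrenergic receptor alpha-1 (Rattus norvegicus), read by radioligand binding (on this read-out lower numbers stand for stronger inhibition and higher numbers for weaker inhibition), and stands second highest of the three numbers measured so far. Compound 1 `COc1ccccc1N1CCN(CCn2nc(-n3cnc4ccccc43)ccc2=O)CC1` gives 33 nM, while compound 3 `O=c1ccc(-n2ccnc2)nn1CCN1CCN(c2ccccc2Cl)CC1` gives 472 nM. The step of a 7.2-fold higher number from compound 1 to compound 2 (0.86 log units; beyond the scatter) is beyond the scatter, whereas a 2.0-fold higher number from compound 2 to compound 3 (0.30 log units; within the scatter) lies within it. Compound 4 `COc1ccccc1N1CCN(CCn2nc(-n3ccc4ccccc43)ccc2=O)CC1` differs from compound 2 by 1H-indol-1-yl in place of 1H-imidazol-1-yl on an aromatic carbon. Among the compounds with values here, the bearing step is the one from compound 1 to compound 2, where a bicyclic group at this position went with a markedly lower number than a single five-membered ring; the present change runs the other way, so a lower number of comparable size is expected for compound 4, that is a 5.3-fold lower number from compound 2 to compound 4 (0.72 log units; beyond the scatter). Compound 4 is therefore estimated at 45 nM, with a range from 15 nM to 150 nM.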

Compound 4, inhibition constant: 22.7 nM
Estimate against measurement, compound 4: 2.0-fold (0.30 log units) above; the measured number falls inside the stated range.
By their numbers in this assay, from the lowest: compounds 4 and 1 (each within the scatter of the next); then compounds 2 and 3 (each within the scatter of the next).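

The lower number seen earlier with a bicyclic group recurs at this position: the change gives a 10-fold lower number from compound 2 to compound 4 (1.02 log units; beyond the scatter), so it is not confined to the group in compound 1. The added nitrogen of 1H-benzimidazol-1-yl shows no readable effect here, as a 1.5-fold lower number from compound 1 to compound 4 (0.16 log units; within the scatter) lies within the scatter. No available evidence accounts for these differences.

The compounds shown leave open whether a single six-membered ring, such as phenyl, would give a similarly low number at this position. They also leave open whether an open-chain amine, such as dimethylamino, would.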